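A fourth aromatic group on a shared acid core

The source may hold more compounds than are shown below. What is called first, only, known or untested is meant among the compounds shown, and "the series" means these compounds.

Three compounds have been measured in an in vitro functional assay on HEK285-7 cells for antagonist activity at prostaglandin D2 receptor 2 (Homo sapiens), read by BRET and beta-arrestin recruitment; on this read-out higher numbers stand for larger maximal responses and lower numbers for smaller maximal responses:

compound 1, `O=C(O)Cc1sc(C(c2ccc(F)cc2)c2ccc(F)cc2)nc1-c1ccnc(F)c1`, gives 80%
compound 2, `NS(=O)(=O)c1cccc(-c2nc(C(c3ccc(F)cc3)c3ccc(F)cc3)sc2CC(=O)O)c1`, gives 55%
compound 3, `O=C(O)Cc1sc(C(c2ccc(F)cc2)c2ccc(F)cc2)nc1-c1cccc(F)c1`, gives 80%

Compound 3 stands level with compound 1; the step of no change at the digits printed from compound 1 to compound 3 (within the scatter) lies within the scatter, so the two cannot be told apart. Both stand clearly above compound 2: the step of a number 25 percentage points higher from compound 2 to compound 3 (beyond the scatter) and the step of a number 25 percentage points lower from compound 1 to compound 2 (beyond the scatter) are each beyond the scatter. Exchanging the fluorinated six-membered ring of compound 1 for that of compound 3 thus left the maximal response untouched, whereas a sulfamoyl group in that position lowered it.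

Compound 4, `O=C(O)Cc1sc(C(c2ccc(F)cc2)c2ccc(F)cc2)nc1-c1ccnc(Cl)c1`, is the next compound to be tested in this assay. Its difference from compound 3 is 2-chloropyridin-4-yl in place of 3-fluorophenyl on an aromatic carbon.

Going by the values given here, the one measured step that bears on this change is the step between compound 1 and compound 3, which swapped a 2-fluoropyridin-4-yl group for a 3-fluorophenyl group without any change beyond the scatter. Among the compounds with values here, compound 4 returns to a pyridine ring of the same kind, now carrying chlorine instead of fluorine; no measured pair speaks to that halogen exchange. The expectation is therefore a step of a number 2 percentage points lower from compound 3 to compound 4 (within the scatter) from compound 3 to compound 4, that is, no change beyond the scatter. For compound 4 the estimated value is 78%, expected to fall between 65% and 90%.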

Compound 4, largest response reached (reported as efficacy), in percent of the reference or control that the assay uses: 80%
Beside the measured number, compound 4's estimate is 2 percentage points below it; measured number inside the range.
By their numbers in this assay, from the lowest: compound 2; then compounds 1, 3 and 4 (each within the scatter of the next).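

In this assay, chloro in place of fluoro on the pyridine ring, the only halogen exchange among these compounds, gives no change at the digits printed from compound 1 to compound 4 (within the scatter), so the two halogens cannot be told apart at this position on this read-out. The ring itself can also differ in its hetero atom and its halogen at once, since 2-chloropyridin-4-yl in place of 3-fluorophenyl gives no change at the digits printed from compound 3 to compound 4 (within the scatter), while 2-chloropyridin-4-yl in place of 3-sulfamoylphenyl gives a number 25 percentage points higher from compound 2 to compound 4 (beyond the scatter), which leaves compound 2 as the only one of the four set apart beyond the scatter. Nothing measured here accounts for these results.

The compounds shown leave open whether a 3-aminophenyl or a 3-carboxyphenyl group at this place would stand with compound 2 or with the other three. They also leave open whether a plain pyridin-4-yl group, with no halogen at all, or a bromo in place of the chloro of compound 4 would keep the maximal response at the same level.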